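Replacing 3-bromophenyl with 2,4,6-trimethoxyphenyl: an expected cytotoxicity step

The compounds below may be only part of what the source reports. "The series", "measured", "known", "first", "only" and "open" are said of these compounds alone.

The compounds here share a large core and differ only in the aromatic group attached to a ring nitrogen. Compound 1 `CC(C)=CCC/C(C)=C/CC/C(C)=C/CC[C@@H]1[C@@]2(C)CC/C(=N\OCc3cn(-c4cccc(Br)c4)nn3)C(C)(C)[C@@H]2CC[C@@]1(C)O` was measured in a functional assay on MCF7 cells (Homo sapiens) for cytotoxicity, read by MTT assay, with a stated time of 48 h; on this read-out higher numbers stand for weaker inhibition and lower numbers for stronger inhibition; in it compound 1 gives 24800 nM. Compound 2 `CC(C)=CCC/C(C)=C/CC/C(C)=C/CC[C@@H]1[C@@]2(C)CC/C(=N\OCc3cn(-c4cccc(C(F)(F)F)c4)nn3)C(C)(C)[C@@H]2CC[C@@]1(C)O` carries trifluoromethyl in place of bromo on an aromatic carbon, and in this assay compound 2 gives 21400 nM. The step is a 1.2-fold lower number from compound 1 to compound 2 (0.06 log units; within the scatter), so the two measured compounds cannot be told apart, and compound 1 has no standing as a stronger or weaker member of the pair.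

Compound 3 `COc1cc(OC)c(-n2cc(CO/N=C3\CC[C@]4(C)[C@@H](CC/C=C(\C)CC/C=C(\C)CCC=C(C)C)[C@](C)(O)CC[C@H]4C3(C)C)nn2)c(OC)c1` has not been measured. Its change from compound 1 is 2,4,6-trimethoxyphenyl in place of 3-bromophenyl on an aromatic nitrogen. Within the data shown here, the only measured step, from compound 1 to compound 2, also exchanged a group on the same aromatic ring and stayed within the scatter; it is the sole guide, and it suggests no change beyond the scatter, although the present exchange replaces the whole aromatic group rather than one substituent. In this assay compound 3 is therefore expected to give 25000 nM, within 8000 nM to 75000 nM. This estimate means an expected step of a 1.0-fold higher number from compound 1 to compound 3 (0.00 log units; within the scatter).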

Compound 3, half-maximal inhibitory concentration: 14700 nM
Estimate against measurement, compound 3: 1.7-fold (0.23 log units) above; the measured number falls inside the stated range.
By their numbers in this assay, from the lowest: compounds 3, 2 and 1 (each within the scatter of the next).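

Until now, only one substituent on the aromatic ring had been exchanged; compound 3 shows that the whole aromatic group on the aromatic nitrogen can be replaced while the number stays within the scatter in this assay, with a 1.7-fold lower number from compound 1 to compound 3 (0.23 log units; within the scatter) and a 1.5-fold lower number from compound 2 to compound 3 (0.16 log units; within the scatter). This holds even though the entering 2,4,6-trimethoxyphenyl has 12 heavy atoms and 3 hydrogen-bond acceptors, whereas the leaving 3-bromophenyl has 7 heavy atoms and 0 hydrogen-bond acceptors. No measurement shown explains why the numbers for these three compounds stay so close.

On these data alone, all three compounds carry a six-membered aromatic ring of carbon only at this place, so it remains open whether a simple alkyl chain there, or a ring bearing an amine or a carboxylic acid, would give a step beyond the scatter. It is also open whether any exchange at this position can move the number far from the values seen here, since none of the steps shown leaves the scatter.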